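A few compounds are considered here, and "the series" means these few. Any claim that something is new, unique, unknown or untested is made for them only; others in the source may bear on it.

Compound 1 `CN1CCN(C23CC(NCCC(=O)N4CCCC4)C(C(c4ccccc4)C2)C(c2ccccc2)C3)CC1`: 21500 nM
Compound 2 `CCN(CC)CCCN1CCC2(N3CCN(C)CC3)CC(c3ccccc3)C1C(c1ccccc1)C2`: 68100 nM
Compound 3 `CN1CCN(C23CCN(CCCN4CCCC4)C(C(c4ccccc4)C2)C(c2ccccc2)C3)CC1`: 43500 nM

All three values come from an ADME assay on L6 cells (Rattus norvegicus) for cytotoxicity, read by fluorescence, with a stated time of 72 h; on this read-out lower numbers stand for stronger inhibition and higher numbers for weaker inhibition. Compound 1 has the lowest number of the three, with compound 3 and compound 2 both higher.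

Compound 4 `CCN(CC)CCC(=O)NC1CC2(N3CCN(C)CC3)CC(c3ccccc3)C1C(c1ccccc1)C2` has not yet been measured. Its difference from compound 1 is (2-(diethylamino)ethyl)carbonyl in place of 2-((pyrrolidin-1-yl)carbonyl)ethyl on an amine nitrogen. Within the data shown here, only one measured step bears on this change, and only in part. It exchanges diethylamino and pyrrolidin-1-yl on a saturated chain carbon, and it amounts to a 1.6-fold lower number from compound 2 to compound 3 (0.19 log units; within the scatter). Among the measured compounds shown here, compound 4 carries the diethylamino group, as compound 2 does, but no measured step covers the full exchange on the amine nitrogen. Because that one related step is only a 1.6-fold lower number from compound 2 to compound 3 (0.19 log units; within the scatter), no large shift is expected in this assay. At most a small rise is anticipated, and it may not exceed the scatter. The expected change is a 1.4-fold higher number from compound 1 to compound 4 (0.14 log units; within the scatter). For compound 4 the estimated value is 30000 nM, with an expected range from 12000 nM to 75000 nM.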

Compound 4, half-maximal inhibitory concentration: 35900 nM
Beside the measured number, compound 4's estimate is 1.2-fold (0.08 log units) below it; the range from low to high includes it.
By their numbers in this assay, from the lowest: compounds 1, 4, 3 and 2 (each within the scatter of the next, the first and the last beyond it).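

In this assay, the change on the amine nitrogen gives a 1.7-fold higher number from compound 1 to compound 4 (0.22 log units; within the scatter), so replacing 2-((pyrrolidin-1-yl)carbonyl)ethyl with (2-(diethylamino)ethyl)carbonyl leaves the number within the scatter. The earlier step exchanged only the two terminal amine groups on a chain without a carbonyl, whereas this one involves an amide-bearing substituent on the amine nitrogen, with the ring opened and the carbonyl placed directly on that nitrogen, and even this larger rearrangement of the same nine heavy atoms does not move the read-out beyond the scatter. No supporting evidence is available to explain this result.

The separate contributions of the diethylamino exchange and the carbonyl placement remain unresolved, as the two occur together in this step. On these data alone, it also remains open whether a carboxylic acid or a longer chain on the amine nitrogen would shift the number beyond the scatter.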